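Amino for hydrogen on the chloro-bearing ring of compound 2

The source may hold more compounds than are shown below. What is called first, only, known or untested is meant among the compounds shown, and "the series" means these compounds.

For the measured compounds named here, compound 2 `Nc1nc(N)c2c(Cl)cccc2n1` holds the lowest number of the two measured so far: in an assay for inhibition of Dihydrofolate reductase (Rattus norvegicus) (on this read-out higher numbers stand for weaker inhibition and lower numbers for stronger inhibition), compound 2 gives 562 nM, whereas compound 1 `Nc1nc(N)c2c(S(=O)(=O)c3ccc(Cl)c(Cl)c3)cccc2n1` gives 57500 nM, a gap beyond the scatter. Compound 3 `Nc1nc(N)c2c(Cl)c(N)ccc2n1` has not been measured; it differs from compound 2 by amino in place of hydrogen on an aromatic carbon. Going by the values given here, no step between measured compounds informs this change, so a small shift in either direction, or none beyond the scatter, is expected. The estimate for compound 3 is 400 nM, with a range of 100 nM to 2000 nM, meaning an expected step of a 1.4-fold lower number from compound 2 to compound 3 (0.15 log units; within the scatter).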

Compound 3, half-maximal inhibitory concentration: 661 nM
Estimate against measurement, compound 3: 1.7-fold (0.22 log units) below, and the stated range covers the measured number.
By their numbers in this assay, from the lowest: compounds 2 and 3 (each within the scatter of the next); then compound 1.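

In this assay, this position on the chloro-bearing ring accepts amino in place of hydrogen, ortho to a chloro group, with a 1.2-fold higher number from compound 2 to compound 3 (0.07 log units; within the scatter), so this aromatic carbon can carry a substituent without a change beyond the scatter. For the compounds shown here, this is the first single-place step, and it offers no support for a gain or a loss from amino here. Nothing at hand explains the result. Still open, as far as these compounds go, is whether a methoxy, a carboxylic acid or a longer chain on this carbon would give a similar number. Also open, from the compounds shown here alone, is how amino behaves at the other carbons of this ring.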